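Cycloalkyl ether series: methyl removal from compound 2

This account rests on a few compounds, and the source may have more. Where it says the series, first, only, none or still open, it means among the compounds named here.

Within the data shown here, compound 2 `CC1CCCC(Oc2cccc3ccc(N)nc23)C1` is the only member of this small set with a number in an assay on cells with melanin-concentrating hormone receptor 1 (Homo sapiens) as the target, read by radioligand binding; a higher number here means a weaker inhibitor, a lower number a stronger inhibitor; there compound 2 gives 640 nM. Compound 1 `Nc1ccc2cccc(OC3CCC3)c2n1` reaches only a limit of the assay: in this assay compound 1 gives > 2000 nM. The set thus holds one number and one limit, (the limit of > 2000 nM in this assay, at which 1 of the 2 values shown sits). Compound 3 `Nc1ccc2cccc(OC3CCCCC3)c2n1` differs from compound 2 by hydrogen in place of methyl on a saturated ring carbon of a six-membered non-aromatic ring of carbon only. Among the measured compounds shown here, no step between two measured compounds is available, so the size of this change cannot be read from the series; a modest loss or no change beyond the scatter is the working expectation. For compound 3 in this assay the estimate is 1000 nM, with a range of 350 nM to 3000 nM. The step of a 1.6-fold higher number from compound 2 to compound 3 (0.19 log units; within the scatter) is expected to be small, toward weaker inhibition.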

Compound 3, half-maximal inhibitory concentration: 361 nM
For compound 3 the middle estimate is 2.8-fold (0.44 log units) above the measured one; the measured number falls inside the stated range.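

In this assay, hydrogen in place of methyl on a saturated ring carbon gives a 1.8-fold lower number from compound 2 to compound 3 (0.25 log units; within the scatter), so the methyl is not needed to keep a number in this range. Ring size on the ether oxygen now has a first reading, with cyclohexyl in place of cyclobutyl giving an at least 5.5-fold lower number from compound 1 to compound 3 (0.74 log units; beyond the scatter). Compound 1 stands at a limit of the assay and not at a number, so the full size of that step stays unknown: the limit of > 2000 nM in this assay, at which 1 of the 3 values shown sits.

Going by these compounds, whether a larger ring such as cycloheptyl, or an open chain such as isopropyl, on the oxygen would hold the number remains open. So does how a hydroxyl or an amine on the cyclohexyl ring would read, and how a methyl would read on the other ring carbons.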